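Removing the acetyl from the anilide of compound 2

A few compounds are considered here, and "the series" means these few. Any claim that something is new, unique, unknown or untested is made for them only; others in the source may bear on it.

Measured compounds:
compound 1 `Cn1c(-c2ccc(-c3cncnc3)cc2)nnc1C1(c2ccc(Cl)cc2)CCC1`: > 4000 nM
compound 2 `CC(=O)Nc1ccc(-c2nnc(C3(c4ccc(Cl)cc4)CCC3)n2C)c(Cl)c1`: > 4000 nM

Both measured compounds were read in an assay on isolated protein for inhibition of 11-beta-hydroxysteroid dehydrogenase type 2 (Homo sapiens); on this read-out higher numbers stand for weaker inhibition and lower numbers for stronger inhibition. For compound 1 the value > 4000 nM is a limit of the assay, not a number. For compound 2 the value > 4000 nM is likewise a limit. Compound 2 therefore stands where every value shown stands, at the limit of > 4000 nM in this assay, at which 2 of the 2 values shown sit. Going by the values given here, no step between measured compounds can be read from this set. Compound 3 `Cn1c(-c2ccc(N)cc2Cl)nnc1C1(c2ccc(Cl)cc2)CCC1` differs from compound 2 by hydrogen in place of acetyl on a nitrogen on an aromatic ring. Nothing shown points to a step in either direction beyond the usual scatter, and compound 2 itself gives only a limit to start from. For compound 3 the expected step from compound 2 is a step that the limit leaves unreadable from compound 2 to compound 3. The value expected for compound 3 in this assay is 5000 nM, within 1500 nM to 20000 nM, with a fair chance that the assay again reports only a limit.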

Compound 3, half-maximal inhibitory concentration: 2300 nM
Compound 3: middle estimate off by 2.2-fold (0.34 log units), on the high side, within the range that was stated.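

In this assay, going by these compounds alone, compound 3, which carries a free amino group on the aromatic ring, gives 2300 nM, the only value shown that is a number rather than a limit. Compound 2 gives only a limit of the assay, > 4000 nM. The change from acetamido to amino on this nitrogen therefore reads as an at least 1.7-fold lower number from compound 2 to compound 3 (0.24 log units; that floor lies within the scatter), so this position yields a readable value once the acetyl has left, but the step has only a floor, and that floor does not clear the usual scatter.

Going by these compounds, the true size of the step remains open, as compound 2 offers no number to measure it from. On these data alone, it also remains open how this assay would read a methylamino group, a dimethylamino group or a urea at the same place.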